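A few compounds are considered here, and "the series" means these few. Any claim that something is new, unique, unknown or untested is made for them only; others in the source may bear on it.

Compound 2 `O=C([C@@H]1C[C@H]1c1cccc(N2CCCC2=O)c1)N1CCN(C2CCC2)CC1` reaches only > 4130000 nM in a physicochemical assay for solubility, at pH 7.4 (on this read-out lower numbers stand for lower solubility and higher numbers for higher solubility), which is a limit of the measurement rather than a number, as the limit of > 4130000 nM in this assay, at which 1 of the 2 values shown sits, shows. Compound 1 `O=C([C@H]1C[C@@H]1c1cccc(N2CCCCC2=O)c1)N1CCN(C2CCC2)CC1` gives 2190000 nM in this assay. Compound 3 `O=C([C@@H]1C[C@H]1c1cccc(N2CCCCC2=O)c1)N1CCN(C2CCC2)CC1` has not yet been measured. It differs from compound 2 by 2-oxopiperidin-1-yl in place of 2-oxopyrrolidin-1-yl on an aromatic carbon, in words 2-oxopiperidin-1-yl in place of 2-oxopyrrolidin-1-yl on an aromatic carbon. Going by the values given here, no measured pair shows this step, so the expected change is small, within the scatter, giving an estimated step of an at least 1.3-fold lower number from compound 2 to compound 3 (0.13 log units; that floor lies within the scatter). Compound 3 is therefore expected at 3000000 nM, with a range from 1200000 nM to 6000000 nM.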

Compound 3, solubility: > 3000000 nM
Compound 3: no number, only a limit (the forecaster's own chance of this, stated with the estimate: 40%); the middle value sits exactly at the limit.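

In this assay compound 3 carries only a limit, > 3000000 nM. Inverting both stereocentres gives an at least 1.3-fold higher number from compound 1 to compound 3 (0.13 log units; that floor lies within the scatter): the fact that compounds 1 and 3 differ only in the configuration as drawn. The step from 2-oxopyrrolidin-1-yl to 2-oxopiperidin-1-yl cannot be read, as compound 2 and compound 3 both carry limits.

Going by these compounds, the actual values of compound 2 and compound 3 in this assay remain open, and with them any effect of ring size at this aromatic carbon. Also open, on these data alone, is how a carboxylic acid or an amine on the same carbon would read in this assay.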